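The source may report more compounds than this note shows. Statements on the series, on what has been measured and on what is new or still open speak of the compounds shown alone.

Measured compounds:
compound 1 `O=C(O)c1ccccc1-c1ccccc1C(=O)NCCCCCCCn1cc(-c2cccnc2)nn1`: 38.5 nM
compound 2 `O=C(NCCCCCCCn1cc(-c2cccnc2)nn1)c1ccccc1-c1c[nH]nn1`: 42.5 nM
compound 3 `O=C(NCCCCCCCn1cc(-c2cccnc2)nn1)c1ccccc1-n1cc(CN2CCC(O)CC2)nn1`: 41.8 nM

In an assay for inhibition of Nicotinamide phosphoribosyltransferase (Mus musculus), read by fluorescence, with a stated time of 1 h, in the presence of a further agent that is not named here (on this read-out lower numbers stand for stronger inhibition and higher numbers for weaker inhibition), compound 3 gives 41.8 nM, the second highest of the three numbers, yet all three lie within the scatter of one another. Compound 4 `CC(C)N1CCN(Cc2cn(-c3ccccc3C(=O)NCCCCCCCn3cc(-c4cccnc4)nn3)nn2)CC1` is the untested member; it differs from compound 3 by 4-isopropylpiperazin-1-yl in place of 4-hydroxypiperidin-1-yl on a saturated chain carbon bound to an aromatic carbon. Going by the values given here, the only measured step, a 1.1-fold higher number from compound 1 to compound 2 (0.04 log units; within the scatter), alters a different part of the shared core and stays within the scatter, so no measured step touches the group that changes here. Given that the three measured numbers sit so close together, compound 4 is expected to show no step beyond the scatter, a 1.0-fold higher number from compound 3 to compound 4 (0.00 log units; within the scatter). Compound 4 is therefore estimated at 42 nM, in the range 18 nM to 100 nM.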

Compound 4, half-maximal inhibitory concentration: 24.7 nM
Estimate against measurement, compound 4: 1.7-fold (0.23 log units) above; low and high end bracket the measured number.
By their numbers in this assay, from the lowest: compounds 4, 1, 3 and 2 (each within the scatter of the next).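

In this assay, going by these compounds alone, the step of a 1.7-fold lower number from compound 3 to compound 4 (0.23 log units; within the scatter) is the first to touch this position, and it shows that (4-isopropylpiperazin-1-yl)methyl can stand in place of (4-hydroxypiperidin-1-yl)methyl with no difference beyond the scatter. The entering group has more heavy atoms and no hydrogen-bond donor, yet the step stays within the scatter. No measurement on hand bears on the reason for this small step. Still open, as far as these compounds go, is whether a carboxylic acid or a primary amine on the same saturated chain carbon would keep the number within the scatter. Also open, from the compounds shown here alone, is whether a longer chain there would do so.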